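The source may hold more compounds than are shown below. What is called first, only, known or untested is meant among the compounds shown, and "the series" means these compounds.

Measured so far in a toxicity assay on Huh-7.5 cells (Homo sapiens) for inhibition, read by MTT assay, with a stated time of 96 h; on this read-out higher numbers stand for lower toxicity in this test and lower numbers for higher toxicity in this test:
- compound 1 `CC1CCN(c2ccc(NC(=O)c3ccc(OCCCCl)c([N+](=O)[O-])c3)cn2)CC1`: 9200 nM
- compound 2 `CN1CCN(Cc2ccc(NC(=O)c3ccc(OCCCCl)c(Cl)c3)cc2C(F)(F)F)CC1`: 4100 nM

Compound 2 holds the lower of the two numbers, and the gap up to compound 1 lies beyond the scatter. The two compounds differ in more than one place, so their values say nothing about any single change.

Compound 3 `CN1CCN(Cc2ccc(NC(=O)c3ccc(OCCCCl)c(C(F)(F)F)c3)cc2C(F)(F)F)CC1` has not been measured. It keeps the core of compound 2 and differs by one change, trifluoromethyl in place of chloro on an aromatic carbon, ortho to a 3-chloropropoxy group.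

Among the compounds with values here, the series offers no measured step for this exchange, or for any other single change. The expectation therefore starts from compound 2 at 4100 nM. In this assay no shift beyond the scatter is expected, with only a slight lean towards a lower number. The expected move is a 1.1-fold lower number from compound 2 to compound 3 (0.06 log units; within the scatter). For compound 3 the estimated value is 3600 nM, with an expected range of 1800 nM to 7200 nM.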

Compound 3, half-maximal cytotoxic concentration: 13400 nM
For compound 3 the middle estimate is 3.7-fold (0.57 log units) below the measured one, and the stated range ends below it.
By their numbers in this assay, from the lowest: compound 2; then compounds 1 and 3 (each within the scatter of the next).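

In this assay, trifluoromethyl in place of chloro on an aromatic carbon, ortho to a 3-chloropropoxy group, gives a 3.3-fold higher number from compound 2 to compound 3 (0.51 log units; beyond the scatter). Within the data shown here, this is the first single-place step, and it shows that this position affects the read-out, with the exchange moving towards lower toxicity in this test by more than the scatter. The exchange replaces 1 heavy atom with 4 heavy atoms and changes neither the hydrogen-bond donor and acceptor counts nor the net charge, but no measurement bears on why the number moves.

This single exchange on one background leaves open whether the step reflects a trend at this carbon, and how a nitrile, a methoxy group or a plain hydrogen would read there. Also open, going by these compounds, is whether the step carries over to a background with an amine other than the methylpiperazine of compound 3, or with a longer chain in place of the 3-chloropropoxy group, since compound 1 differs from compound 3 in more than one place and cannot settle this.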